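The source may report more compounds than this note shows. Statements on the series, on what has been measured and on what is new or still open speak of the compounds shown alone.

The three measured compounds, all read in an ADME assay on HEK293 cells (Homo sapiens) for cytotoxicity, read by MTT assay, with a stated time of 48 h; on this read-out lower numbers stand for stronger inhibition and higher numbers for weaker inhibition:

Compound 1, `COc1cc(NC(=O)c2cccc(C(F)(F)F)c2)ccc1NS(=O)(=O)C(F)(F)F`, gives > 250000 nM, which is a limit of the assay.
Compound 2, `COc1cc(NC(=O)c2cc(C(F)(F)F)cc(C(F)(F)F)c2)ccc1NS(=O)(=O)C(F)(F)F`, gives > 250000 nM, also a limit of the assay.
Compound 3, `CS(=O)(=O)Nc1ccc(NC(=O)c2cccc(C(F)(F)F)c2)cc1Cl`, gives > 250000 nM, again a limit of the assay.

Compound 1 and compound 2 share one core and differ by a single change, (trifluoromethyl in place of hydrogen on an aromatic carbon). Since both values are limits, the step that the two limits leave unreadable from compound 1 to compound 2 cannot be read: all that is known is that neither compound reached a measurable number. Within the data shown here, this is the setting described by the limit of > 250000 nM in this assay, at which 3 of the 3 values shown sit, where every value so far sits.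

Compound 3 carries a different core; the difference between the two cores is not broken down here. The unmeasured compound 4, `CS(=O)(=O)Nc1ccc(NC(=O)c2cc(C(F)(F)F)cc(C(F)(F)F)c2)cc1Cl`, is made from compound 3 by the same change, (trifluoromethyl in place of hydrogen on an aromatic carbon), at a place described in the same words as before.

What to expect for compound 4 in this assay rests only on the fact that the same change from compound 1 to compound 2 left both compounds at the limit, and that compound 3 also sits at the limit. The step from compound 3 to compound 4 is therefore expected to be a step that the limit leaves unreadable from compound 3 to compound 4, with no readable size. Compound 4 is expected to give 300000 nM, most likely reported again as a limit rather than a number.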

Compound 4, half-maximal inhibitory concentration: 185000 nM
Estimate against measurement, compound 4: 1.6-fold (0.21 log units) above, within the range that was stated.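

In this assay, the change gives an at least 1.3-fold lower number from compound 3 to compound 4 (0.13 log units; that floor lies within the scatter), so on the core of compound 3 a trifluoromethyl in place of hydrogen goes along with a measured number, but the smallest step the values allow cannot be told apart from repeat-to-repeat variation. On the core of compound 1, the same change cannot be read, and the two steps cannot be set side by side, as most values shown rest at one ceiling: the limit of > 250000 nM in this assay, at which 3 of the 4 values shown sit. Among these compounds, the series therefore shows only that the change can bring a measured value on one core; it does not show that the change acts alike on both cores, or how large its true step is on either.

The compounds shown leave open what an amine or a carboxylic acid would give on the same aromatic carbon in place of the added trifluoromethyl, and whether a longer chain there would also bring a measured value. They also leave open whether the same change would give a readable step on the core of compound 1 under conditions where that compound gives a number rather than a limit.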